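Dropping one methoxy from the trimethoxyphenyl pyrazole

The compounds below may be only part of what the source reports. "The series", "measured", "known", "first", "only" and "open" are said of these compounds alone.

Compound 1 `COc1ccc(-c2cc(/C=C/C(=O)c3ccc(N)cc3)[nH]n2)cc1`: 46900 nM
Compound 2 `COc1cc(-c2cc(/C=C/C(=O)c3ccc(N)cc3)[nH]n2)cc(OC)c1OC`: 86500 nM
Compound 3 `COc1cc(-c2cc(/C=C/C(=O)c3ccc(F)c(F)c3)[nH]n2)cc(OC)c1OC`: > 100000 nM (a limit of the assay)

In a functional assay on A549 cells (Homo sapiens) for inhibition, read by sulforhodamine B assay, with a stated time of 48 h (a higher number here means that more compound is tolerated, a lower number that less compound is tolerated), compound 2 gives 86500 nM. Compound 1 gives 46900 nM, and the two numbers lie within the scatter of each other, so no order between them can be claimed. Compound 3 reports only a limit, > 100000 nM; the value sits at the limit of > 100000 nM in this assay, at which 1 of the 3 values shown sits.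

Compound 4 `COc1ccc(-c2cc(/C=C/C(=O)c3ccc(N)cc3)[nH]n2)cc1OC` differs from compound 2 by hydrogen in place of methoxy on an aromatic carbon. Among the compounds with values here, the one measured step, an at least 1.1-fold higher number from compound 2 to compound 3 (0.06 log units; that floor lies within the scatter), changes the aryl group on the carbonyl, not the methoxy pattern, so it does not bear on this change. Compound 1 and compound 2 differ by two methoxy groups, which is not a single step, and their values merely show that the two methoxy patterns give numbers within the scatter of each other. Compound 4 sits between those two patterns, and on that basis no step beyond the scatter is expected.

Compound 4 is therefore expected to give 60000 nM in this assay, within 30000 nM to 100000 nM, which means an expected step of a 1.4-fold lower number from compound 2 to compound 4 (0.16 log units; within the scatter).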

Compound 4, concentration lethal to 50% of the cells: 45200 nM
For compound 4 the middle estimate is 1.3-fold (0.12 log units) above the measured one; low and high end bracket the measured number.
By their numbers in this assay, from the lowest: compounds 4, 1 and 2 (each within the scatter of the next). At a limit, above all of these: compound 3.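

In this assay, within the data shown here, the methoxy pattern on this aromatic ring can now be read in single steps for the first time: hydrogen in place of methoxy gives a 1.9-fold lower number from compound 2 to compound 4 (0.28 log units; within the scatter), and methoxy in place of hydrogen gives a 1.0-fold lower number from compound 1 to compound 4 (0.02 log units; within the scatter). Compound 1 and compound 2 differ in two places, so they could not show this, whereas compound 4 shows that changing either methoxy alone, including the one ortho to a methoxy group and meta to a large group, leaves the number within the scatter, and no order among the three compounds can be claimed. Nothing in the data at hand accounts for how close these numbers lie.

Going by these compounds, it remains open whether a hydroxyl group or an ethoxy group at this position would carry the number beyond the scatter. On these data alone, it is also open whether the methoxy change reads the same with 3,4-difluorophenyl on the carbonyl carbon, as in compound 3, whose value is only a limit of the assay.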